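The source may report more compounds than this note shows. Statements on the series, on what has been measured and on what is new or still open speak of the compounds shown alone.

Compounds measured in a functional assay on DU-145 cells (Homo sapiens) for cytotoxicity, read by MTT assay, with a stated time of 48 h; on this read-out lower numbers stand for stronger inhibition and higher numbers for weaker inhibition: compound 1 `c1ccc(-c2nc(-c3c[nH]c4ccccc34)co2)cc1` gives 167000 nM; compound 2 `Fc1ccc(-c2nc(-c3c[nH]c4ccccc34)co2)cc1` gives 31800 nM; compound 3 `C=Cc1nc(-c2c[nH]c3ccccc23)co1` gives 59800 nM.

Compound 1 stands with the highest number of the three; the step of a 5.3-fold lower number from compound 1 to compound 2 (0.72 log units; beyond the scatter) and the step of a 2.8-fold lower number from compound 1 to compound 3 (0.45 log units; beyond the scatter) both lie beyond the scatter. Compound 4 `c1ccc2c(-c3coc(C4CCNCC4)n3)c[nH]c2c1` differs from compound 1 by piperidin-4-yl in place of phenyl on an aromatic carbon. Both measured steps from compound 1 alter this same position and both lowered the number, yet neither places a non-aromatic ring with a hetero atom there, so they bear on the new step only loosely. A lowering of modest size is therefore expected, a 2.1-fold lower number from compound 1 to compound 4 (0.32 log units; beyond the scatter), with wide uncertainty. Compound 4 is estimated at 80000 nM, expected to fall within 20000 nM to 300000 nM.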

Compound 4, half-maximal inhibitory concentration: 381000 nM
Compound 4: the middle estimate sits 4.8-fold (0.68 log units) below what was measured, and the stated range ends below it.
By their numbers in this assay, from the lowest: compounds 2 and 3 (each within the scatter of the next); then compound 1; then compound 4.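

In this assay, going by these compounds alone, the step of a 2.3-fold higher number from compound 1 to compound 4 (0.36 log units; beyond the scatter) is the first change at this position to raise the number, so replacing the phenyl does not lower it in every case. Piperidin-4-yl also sits well apart from the other replacements, with a 6.4-fold higher number from compound 3 to compound 4 (0.80 log units; beyond the scatter) and a 12-fold higher number from compound 2 to compound 4 (1.08 log units; beyond the scatter) as the printed steps. Nothing available accounts for this rise.

On these data alone, it remains open whether the ring nitrogen or the non-aromatic ring itself goes with the higher number, a question that cyclohexyl or tetrahydropyran-4-yl at this position could separate. An open-chain amine there is also untested in the compounds shown.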